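The source may hold more compounds than are shown below. What is called first, only, known or untested is meant among the compounds shown, and "the series" means these compounds.

Measured so far in a functional assay on MCF7 cells (Homo sapiens) for antiproliferative activity, read by sulforhodamine B assay, with a stated time of 72 h; a lower number here means a stronger inhibitor, a higher number a weaker inhibitor:
compound 1, `Cc1ccccc1COc1ccc(-c2cc(CN3CCN(Cc4ccc(C(F)(F)F)cc4)CC3)no2)cc1`, gives 3700 nM
compound 2, `Cc1ccc(COc2ccc(-c3cc(CN4CCN(Cc5ccc(C(F)(F)F)cc5)CC4)no3)cc2)cc1`, gives 1200 nM
compound 3, `N#Cc1ccccc1COc1ccc(-c2cc(CN3CCN(Cc4ccc(C(F)(F)F)cc4)CC3)no2)cc1`, gives 4000 nM

Among these three numbers compound 1 holds the second highest. Compound 3 sits nearest to it, with a 1.1-fold higher number from compound 1 to compound 3 (0.03 log units; within the scatter), and compound 2 sits furthest, with a 3.1-fold lower number from compound 1 to compound 2 (0.49 log units; beyond the scatter).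

Compound 4, `COc1cc(COc2ccc(-c3cc(CN4CCN(Cc5ccc(C(F)(F)F)cc5)CC4)no3)cc2)cc(OC)c1`, has not yet been measured in this assay. It differs from compound 1 in one place: 3,5-dimethoxyphenyl in place of 2-methylphenyl on a saturated chain carbon bound to an oxygen on an aromatic ring. Among the compounds with values here, two measured steps bear on this change. The step of a 3.1-fold lower number from compound 1 to compound 2 (0.49 log units; beyond the scatter) shows that replacing 2-methylphenyl by 4-methylphenyl at that place shifts the number by a modest amount, while the step of a 1.1-fold higher number from compound 1 to compound 3 (0.03 log units; within the scatter) shows that exchanging a methyl for a cyano on the aromatic carbon leaves the number essentially unchanged. Within the data shown here, the change to 3,5-dimethoxyphenyl is larger than either of these, and no measured compound carries a methoxy group, so the outcome is uncertain. The expectation for compound 4 is a modest move toward a lower number, of about the size a 2.1-fold lower number from compound 1 to compound 4 (0.31 log units; beyond the scatter). Compound 4 is therefore estimated at 1800 nM, with a range from 700 nM to 4500 nM.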

Compound 4, half-maximal inhibitory concentration: 100 nM
Compound 4: middle estimate off by 18-fold (1.26 log units), on the high side; the measured number lies below the stated range.
By their numbers in this assay, from the lowest: compound 4; then compound 2; then compounds 1 and 3 (each within the scatter of the next).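

In this assay, swapping the group on a saturated chain carbon bound to an oxygen on an aromatic ring had given only modest shifts or none among compound 1, compound 2 and compound 3, yet 3,5-dimethoxyphenyl gives a 37-fold lower number from compound 1 to compound 4 (1.57 log units; beyond the scatter) and a 40-fold lower number from compound 3 to compound 4 (1.60 log units; beyond the scatter). Even measured against compound 2, the lowest of those earlier three, the same group gives a 12-fold lower number from compound 2 to compound 4 (1.08 log units; beyond the scatter), so this position can move the number far more than the methyl and cyano variants revealed. Nothing available here explains why this group has such an effect.

The compounds shown leave open whether both methoxy groups are needed: no phenyl carrying a single methoxy group appears among them, so the gain cannot yet be divided between the two groups or tied to where they sit on the ring. From the compounds shown here alone, it also remains open whether other oxygen or nitrogen groups on that ring, such as ethoxy, hydroxy or an amine, would give a similar number, or whether the gain belongs to methoxy alone.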